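Shifting the carboxyl group on a receptor modulator

This account rests on a few compounds, and the source may have more. Where it says the series, first, only, none or still open, it means among the compounds named here.

Compound 1 `COc1cc(C(=O)O)ccc1OCCCCOc1ccc(C(=O)CC(C)C)c(O)c1C`: 614 nM
Compound 2 `Cc1c(OCCCCOc2cccc(C(=O)O)c2)ccc(C(=O)CC(C)C)c1C`: "not determined" (no result reported)
Compound 3 `Cc1c(OCCCCOc2ccc(C(=O)O)cc2)ccc(C(=O)CC(C)C)c1O`: 2720 nM

Among the compounds with values here, in an assay on HEK293 cells for positive allosteric modulation of metabotropic glutamate receptor 3 (Rattus norvegicus), read by thallium flux, with a stated time of 2.5 min (a higher number here means that more compound is needed for the effect, a lower number that less compound is needed), compound 3 gives 2720 nM, the highest of the two numbers known; its nearest neighbour is compound 1, which gives 614 nM. Within the data shown here, the one step between measured compounds, a 4.4-fold higher number from compound 1 to compound 3 (0.65 log units; beyond the scatter), concerns a methoxy group on the shared core and not the carboxyphenyl end of the chain. Compound 2 carries the 3-carboxyphenyl group but gave "not determined" (no result reported), so it offers no number to lean on.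

Compound 4 `Cc1c(OCCCCOc2cccc(C(=O)O)c2)ccc(C(=O)CC(C)C)c1O` differs from compound 3 only by 3-carboxyphenyl in place of 4-carboxyphenyl on an oxygen on a saturated carbon. No measured step bears on this change, so the size and direction of the step in this assay cannot be read from the data shown. In the absence of a relevant step, the estimate for compound 4 is set near compound 3 with a wide range, expected to be 3500 nM (range 900 nM to 14000 nM). This corresponds to an expected step of a 1.3-fold higher number from compound 3 to compound 4 (0.11 log units; within the scatter).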

Compound 4, half-maximal effective concentration: 1430 nM
For compound 4 the middle estimate is 2.4-fold (0.39 log units) above the measured one; low and high end bracket the measured number.
By their numbers in this assay, from the lowest: compound 1; then compounds 4 and 3 (each within the scatter of the next).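

In this assay, within the data shown here, this is the first measured step at the carboxyphenyl end of the chain: 3-carboxyphenyl in place of 4-carboxyphenyl gives a 1.9-fold lower number from compound 3 to compound 4 (0.28 log units; within the scatter). Within the compounds shown, the change at this position therefore stays inside the scatter, whereas the methoxy change on the shared core, a 4.4-fold higher number from compound 1 to compound 3 (0.65 log units; beyond the scatter), lies beyond it. Nothing measured here speaks to why the two carboxyphenyl groups give numbers within the scatter of each other.

Still open, going by these compounds, is how the 3-carboxyphenyl group would behave on a core carrying the methoxy group of compound 1. Also open, on these data alone, is whether the carboxylic acid could give way to an ester or an amide at this end, or how a longer chain would fare with either carboxyphenyl group.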